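Aryl swaps on the shared core: notes toward compound 4

The source may hold more compounds than are shown below. What is called first, only, known or untested is meant among the compounds shown, and "the series" means these compounds.

Measured so far in a functional assay, with a stated time of 10 min; on this read-out higher numbers stand for weaker inhibition and lower numbers for stronger inhibition:
- compound 1, `CCOC(=O)c1cnn(-c2nc(-c3ccc(Cl)cc3)c(C#N)c(=O)n2C)c1N`, gives 94 ug/mL
- compound 2, `CCOC(=O)c1cnn(-c2nc(-c3ccc(OC)cc3)c(C#N)c(=O)n2C)c1N`, gives 74 ug/mL
- compound 3, `CCOC(=O)c1cnn(-c2nc(-c3cccs3)c(C#N)c(=O)n2C)c1N`, gives 109 ug/mL

The three compounds differ only in the aryl group on the shared core. Compound 3 carries the thiophen-2-yl group and gives the highest of the three numbers, but it sits within the scatter of both others: a 1.2-fold higher number from compound 1 to compound 3 (0.06 log units; within the scatter) and a 1.5-fold higher number from compound 2 to compound 3 (0.17 log units; within the scatter). The exchange between compound 1 and compound 2, a 1.3-fold lower number from compound 1 to compound 2 (0.10 log units; within the scatter), is likewise within the scatter. So far, then, no aryl exchange at this position has moved this assay beyond its usual spread.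

Compound 4, `CCOC(=O)c1cnn(-c2nc(-c3ccccc3O)c(C#N)c(=O)n2C)c1N`, is the next step from compound 3. The change is 2-hydroxyphenyl in place of thiophen-2-yl on an aromatic carbon. For the measured compounds named here, no measured step puts a 2-hydroxyphenyl group, or any group bearing a hydrogen-bond donor, at this position, so nothing bears on the change directly. What does bear on it is that every aryl exchange measured here has stayed within the scatter, and the expectation is therefore the same for this one: a 1.1-fold lower number from compound 3 to compound 4 (0.06 log units; within the scatter), with no direction beyond the scatter.

Compound 4 is accordingly estimated at 95 ug/mL in this assay, with a range of 45 ug/mL to 200 ug/mL.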

Compound 4, half-maximal inhibitory concentration: 58 ug/mL
Compound 4: middle estimate off by 1.6-fold (0.21 log units), on the high side, and the stated range covers the measured number.
By their numbers in this assay, from the lowest: compounds 4, 2, 1 and 3 (each within the scatter of the next).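

Compound 4 places a group with a hydrogen-bond donor on this aromatic carbon, ortho to the cyano group, which none of the earlier aryl groups did, and in this assay the number still does not leave the scatter of any earlier compound (a 1.9-fold lower number from compound 3 to compound 4 (0.27 log units; within the scatter); a 1.3-fold lower number from compound 2 to compound 4 (0.11 log units; within the scatter); a 1.6-fold lower number from compound 1 to compound 4 (0.21 log units; within the scatter)). For the compounds shown here, the step from the thiophen-2-yl group is the largest of the steps at this position so far, yet it is printed as within the scatter, so it gives no direction for the 2-hydroxyphenyl change. All four compounds now lie within the scatter of one another, with no exception among them, and nothing shown gives a reason for the number of compound 4 or for the small size of these steps.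

The compounds shown do not separate the hydroxyl from the phenyl ring that carries it, so what each contributes to the step stays open. Also open, on these data alone, is whether an amine or a carboxylic acid on that phenyl ring, or a longer chain in place of the aryl group, would take this assay beyond its usual spread.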